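Series notes: replacing cyclohexylsulfanyl with pyridin-3-yl

The source may hold more compounds than are shown below. What is called first, only, known or untested is meant among the compounds shown, and "the series" means these compounds.

Of the compounds shown here, three sharing one core have been measured in an assay on CHO cells for antagonist activity at transient receptor potential cation channel subfamily V member 1 (Homo sapiens), read by FLIPR; a higher number here means a weaker inhibitor, a lower number a stronger inhibitor. Compound 1 `CC(C(=O)NCc1ccc(C(F)(F)F)cc1N1CCCC1)c1ccc(NS(C)(=O)=O)c(F)c1` gives 2.3 nM, compound 2 `CC(C(=O)NCc1ccc(C(F)(F)F)cc1OCc1ccccc1)c1ccc(NS(C)(=O)=O)c(F)c1` gives 0.9 nM, and compound 3 `CC(C(=O)NCc1ccc(C(F)(F)F)cc1SC1CCCCC1)c1ccc(NS(C)(=O)=O)c(F)c1` gives 0.5 nM. Compound 3 has the lowest number of the three: a 1.8-fold lower number from compound 2 to compound 3 (0.26 log units; within the scatter), which is within the scatter, and a 4.6-fold lower number from compound 1 to compound 3 (0.66 log units; beyond the scatter), which is beyond it. The step of a 2.6-fold lower number from compound 1 to compound 2 (0.41 log units; beyond the scatter) is also beyond the scatter.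

Compound 4 `CC(C(=O)NCc1ccc(C(F)(F)F)cc1-c1cccnc1)c1ccc(NS(C)(=O)=O)c(F)c1` is not yet measured. It differs from compound 3 in one place: pyridin-3-yl in place of cyclohexylsulfanyl on an aromatic carbon. Among the compounds with values here, no measured step introduces pyridin-3-yl, so the only guidance comes from the steps ending at compound 3, a 4.6-fold lower number from compound 1 to compound 3 (0.66 log units; beyond the scatter) and a 1.8-fold lower number from compound 2 to compound 3 (0.26 log units; within the scatter). They show that swapping the group at this position has moved the number by modest amounts, with pyrrolidin-1-yl giving the highest number and benzyloxy and cyclohexylsulfanyl giving numbers within the scatter of each other. Pyridin-3-yl is untested in this series, so a modest rise in the number is expected, a 4.0-fold higher number from compound 3 to compound 4 (0.60 log units; beyond the scatter), though a result within the scatter cannot be excluded. Compound 4 is therefore estimated at 2 nM, with a range from 0.5 nM to 8 nM.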

Compound 4, inhibition constant: 59.4 nM
Beside the measured number, compound 4's estimate is 30-fold (1.47 log units) below it; the measured number lies above the stated range.
By their numbers in this assay, from the lowest: compounds 3 and 2 (each within the scatter of the next); then compound 1; then compound 4.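

In this assay, within the data shown here, this position proves much less permissive than the earlier compounds indicated: pyridin-3-yl in place of cyclohexylsulfanyl gives a 120-fold higher number from compound 3 to compound 4 (2.07 log units; beyond the scatter) and the same group gives a 66-fold higher number from compound 2 to compound 4 (1.82 log units; beyond the scatter) when it replaces benzyloxy, while its replacement of pyrrolidin-1-yl gives a 26-fold higher number from compound 1 to compound 4 (1.41 log units; beyond the scatter) as the third large step. Among these compounds, the three earlier groups differed from one another only modestly or within the scatter, so compound 4 is the first sign in this set that the group on this aromatic carbon can shift the number by a large amount, even with a similar heavy-atom count and the same hydrogen-bond donor and acceptor counts as cyclohexylsulfanyl. Pyridin-3-yl is also the only one of the four groups joined to the aromatic carbon through a ring carbon, but no supporting data bear on what lies behind the rise.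

The compounds shown do not separate the effect of the ring nitrogen from that of the direct ring attachment, a question that phenyl at this position would address. Also open, as far as these compounds go, is how a pyridin-3-ylmethyl group, which keeps the same ring but adds a methylene link as in benzyloxy, or a small open-chain group such as methylsulfanyl would compare with compound 3 and compound 4.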